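Aryl swap on the amide-type nitrogen: compound 3

A few compounds are considered here, and "the series" means these few. Any claim that something is new, unique, unknown or untested is made for them only; others in the source may bear on it.

Compound 2 `COc1cc(Cl)cc(-c2nn(-c3cccc(NC(=O)Nc4ccc(Cl)c(Cl)c4)c3)cc2-c2ccncc2)c1` stands level with compound 1 `COc1cc(Cl)cc(-c2nn(-c3cccc(NC(=O)Nc4ccc(Cl)c(C(F)(F)F)c4)c3)cc2-c2ccncc2)c1` in a functional assay on SN12C cells (Homo sapiens) for inhibition, read by sulforhodamine B assay, with a stated time of 48 h, tested at 0.1 uM; a lower number here means a stronger effect, a higher number a weaker effect of the compound at the concentration tested: compound 2 gives 100%, and compound 1 gives 100%. Going by the values given here, the single measured step, no change at the digits printed from compound 1 to compound 2 (within the scatter), is the only comparison in hand and showed no movement beyond the scatter. Compound 3 `COc1cc(Cl)cc(-c2nn(-c3cccc(NC(=O)Nc4cccc(C(F)(F)F)c4)c3)cc2-c2ccncc2)c1` is not yet measured; it differs from compound 2 by 3-(trifluoromethyl)phenyl in place of 3,4-dichlorophenyl on an amide-type nitrogen. Among the compounds with values here, no measured step alters this part of the molecule in the same way, so the step from compound 1 to compound 2 is the only guide, and there a change of the aryl group on the amide-type nitrogen left this assay unchanged. The step expected here, a number 2 percentage points lower from compound 2 to compound 3 (within the scatter), is therefore none beyond the scatter. For compound 3 the estimate in this assay is 98%, with a range from 85% to 105%.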

Compound 3, a percentage reported as activity, at one concentration (the size of the read-out at that concentration, not a potency): 96%
Compound 3: middle estimate off by 2 percentage points, on the high side, and the stated range covers the measured number.
By their numbers in this assay, from the lowest: compounds 3, 1 and 2 (each within the scatter of the next).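

In this assay the aryl group on the amide-type nitrogen goes from 3,4-dichlorophenyl to 3-(trifluoromethyl)phenyl with a number 4 percentage points lower from compound 2 to compound 3 (within the scatter) as the whole step, so a second aryl swap at this position also stays within the scatter. Going by these compounds alone, with hydrogen in place of chloro on an aromatic carbon, the series gives a number 4 percentage points lower from compound 1 to compound 3 (within the scatter) and, for the first time, shows that chloro removed rather than exchanged, again with no step beyond the scatter. Nothing available explains this flat reading.

On these data alone, all three aryl groups at this position carry only chloro or trifluoromethyl, so an amine or a carboxylic acid on this ring, or cyclohexyl in place of the aryl group, remains open. As far as these compounds go, whether these compounds separate at any other concentration also remains open.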